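The source may hold more compounds than are shown below. What is called first, only, known or untested is meant among the compounds shown, and "the series" means these compounds.

Measured in a functional assay on the whole organism with Mus musculus as the target, in the rotarod test; on this read-out higher numbers stand for an effect only at larger amounts of compound and lower numbers for an effect already at smaller amounts
- compound 1 `CC(=O)NCC(=O)N(C)c1ccc(Cl)cc1C(=O)c1ccccc1Cl` gives 58 mg/kg
- compound 2 `CN1CCN(CC(=O)NCC(=O)N(C)c2ccc(Cl)cc2C(=O)c2ccccc2Cl)CC1` gives > 100 mg/kg, which is a limit
- compound 3 `CCCCCCC(=O)NCC(=O)N(C)c1ccc(Cl)cc1C(=O)c1ccccc1Cl` gives 70 mg/kg

Going by the values given here, compound 3 stands level with the only other number, inside the scatter. That gap is a 1.2-fold higher number from compound 1 to compound 3 (0.08 log units; within the scatter).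

Compound 4 `CN(C(=O)CNC(=O)CN1CCN(c2ccccc2)CC1)c1ccc(Cl)cc1C(=O)c1ccccc1Cl` carries 4-phenylpiperazin-1-yl in place of pentyl on a saturated chain carbon bound to a carbonyl carbon. Among the compounds with values here, compound 2 is the nearest precedent, with 4-methylpiperazin-1-yl at that place. Its steps are an at least 1.4-fold lower number from compound 2 to compound 3 (0.15 log units; that floor lies within the scatter) and an at least 1.7-fold higher number from compound 1 to compound 2 (0.23 log units; that floor lies within the scatter), both floors within the scatter.

In this assay no step beyond the scatter is therefore firmly expected, only a lean towards a higher number, and a limit may again be reported. The expected step is a 1.2-fold higher number from compound 3 to compound 4 (0.08 log units; within the scatter). Compound 4 is estimated at 85 mg/kg, with an expected range from 40 mg/kg to 170 mg/kg.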

Compound 4, dose for half-maximal effect: > 100 mg/kg
Compound 4: no number, only a limit; the forecaster's own chance of this, stated with the estimate: 35%; middle value at least 1.1-fold (0.07 log units) from the limit.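

In this assay compound 4 gives only a limit, not a number, so 4-phenylpiperazin-1-yl at this place, like the 4-methylpiperazin-1-yl of compound 2, yields no readable value. Against pentyl the change reads an at least 1.4-fold higher number from compound 3 to compound 4 (0.15 log units; that floor lies within the scatter), and against hydrogen it reads an at least 1.7-fold higher number from compound 1 to compound 4 (0.23 log units; that floor lies within the scatter), so neither floor clears the scatter. The effect of phenyl in place of methyl on the ring amine nitrogen cannot be read, because both compounds sit at a limit: the limit of > 100 mg/kg in this assay, at which 2 of the 4 values shown sit.

Still open, on these data alone, is whether any piperazine at this place gives a number in this assay. Also open, as far as these compounds go, is where a morpholine or a carboxylic acid at the same place would fall.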